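The source may report more compounds than this note shows. Statements on the series, on what has been measured and on what is new or still open speak of the compounds shown alone.

In a functional assay on CNE-2 cells (Homo sapiens) for inhibition, read by MTT assay, with a stated time of 72 h (on this read-out higher numbers stand for weaker inhibition and lower numbers for stronger inhibition), compound 1 `Nc1ncnc2c1c(-c1cnc3[nH]ccc3c1)nn2CCCCC(=O)NO` gives > 150000 nM, which is a limit of the assay and not a number. Compound 2 `Nc1nc2cc(-c3nn(CCC(=O)NO)c4ncnc(N)c34)ccc2o1` gives > 150000 nM, also only a limit. For the measured compounds named here, that leaves compound 2 with no exact position, and the limit of > 150000 nM in this assay, at which 2 of the 2 values shown sit, offers no measured step to use as a guide. Compound 3 `Nc1nc2cc(-c3nn(CCCCCCCCC(=O)NO)c4ncnc(N)c34)ccc2o1` carries 6-(hydroxycarbamoyl)hexyl in place of hydroxycarbamoyl on a saturated chain carbon, two bonds along the chain from an aromatic nitrogen. A moderate but very uncertain move toward stronger inhibition is expected, with an estimated at least 5.0-fold lower number from compound 2 to compound 3 (0.69 log units; beyond the scatter). The expected value for compound 3 is 30000 nM, with an estimated range of 3000 nM to 150000 nM.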

Compound 3, half-maximal inhibitory concentration: 3240 nM
Compound 3: the middle estimate sits 9.3-fold (0.97 log units) above what was measured, within the range that was stated.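

In this assay, for the compounds shown here, the length of the chain at this position clearly matters: 6-(hydroxycarbamoyl)hexyl in place of hydroxycarbamoyl gives an at least 46-fold lower number from compound 2 to compound 3 (1.66 log units; beyond the scatter), and compound 3 provides the first exact value here. That step is only a minimum and not a measured size, because compound 2 stands at a limit of the assay: the limit of > 150000 nM in this assay, at which 2 of the 3 values shown sit.

With only these two chain lengths shown on this core, it stays open how the number changes at lengths in between. On these data alone, it is also open whether a longer chain would lower it further, or whether a carboxylic acid at the chain end would keep the effect.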